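The source may report more compounds than this note shows. Statements on the series, on what has been measured and on what is new or still open speak of the compounds shown alone.

Compounds measured in a functional assay on MCF7 cells (Homo sapiens) for cytotoxicity, read by MTT assay, with a stated time of 24 h; on this read-out higher numbers stand for weaker inhibition and lower numbers for stronger inhibition:
compound 1 `O=C(CN1CCN(c2ccccc2Cl)CC1)N1CCN(c2nnc(-c3ccccc3)c(-c3ccccc3)n2)CC1`: 263000 nM
compound 2 `COc1cccc(N2CCN(CC(=O)N3CCN(c4nnc(-c5ccccc5)c(-c5ccccc5)n4)CC3)CC2)c1`: > 910000 nM, which is a limit of the assay and not a number
compound 3 `COc1ccccc1N1CCN(CC(=O)N2CCN(c3nnc(-c4ccc(C)cc4)c(-c4ccc(C)cc4)n3)CC2)CC1`: 59400 nM

On the numbers shown, compound 3 stands lowest of the two, with compound 1 above it. Compound 2 is recorded only at the limit of > 910000 nM in this assay, at which 1 of the 3 values shown sits.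

Compound 4 `COc1cccc(N2CCN(CC(=O)N3CCN(c4nnc(-c5ccc(C)cc5)c(-c5ccc(C)cc5)n4)CC3)CC2)c1` differs from compound 3 by 3-methoxyphenyl in place of 2-methoxyphenyl on an amine nitrogen in a ring.

Within the data shown here, only one measured step touches this position: an at least 3.4-fold higher number from compound 1 to compound 2 (0.53 log units; beyond the scatter). That step brings in the same 3-methoxyphenyl that enters in compound 4, though it leaves 2-chlorophenyl rather than 2-methoxyphenyl, and it was read on a core that carries phenyl groups where compound 3 and compound 4 carry 4-methylphenyl groups. It ends at a limit, so its true size is not known. The step from compound 3 to compound 4 is therefore expected to run in the same direction, towards a higher number in this assay, and to be of at least modest size, with a real chance that compound 4 also reaches the limit of the assay; this is the expected step of a 4.2-fold higher number from compound 3 to compound 4 (0.62 log units; beyond the scatter).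

Compound 4 is accordingly estimated at 250000 nM in this assay, with a range from 80000 nM to 900000 nM.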

Compound 4, half-maximal inhibitory concentration: 867000 nM
Estimate against measurement, compound 4: 3.5-fold (0.54 log units) below; the range from low to high includes it.
By their numbers in this assay, from the lowest: compound 3; then compound 1; then compound 4. At a limit, above all of these: compound 2.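

In this assay, among these compounds, a 15-fold higher number from compound 3 to compound 4 (1.16 log units; beyond the scatter), and this is the first step at this position with a readable size. The group that leaves and the group that enters have the same atoms, so the step isolates the placement of the methoxy group on the ring, on an amine nitrogen in a ring, with no change of substituent. Compound 2, which ended the only earlier step at this position, is a limit of the assay and not a number: the limit of > 910000 nM in this assay, at which 1 of the 4 values shown sits. The two steps that bring in 3-methoxyphenyl, one on each core, both go towards a higher number, with no compound shown going against this, but the earlier step also exchanged chlorine for methoxy, so only the new step ties the direction to placement alone.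

Whether the same placement effect holds on the core of compound 1 stays open, as that core carries no matched pair of 2-methoxyphenyl and 3-methoxyphenyl among the compounds shown. Also open, from the compounds shown here alone, is how 4-methoxyphenyl or an unsubstituted phenyl at this position would compare with compound 3 on its core.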